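Triazolylmethyl spiro series: aryl variation on the triazole nitrogen

The source may hold more compounds than are shown below. What is called first, only, known or untested is meant among the compounds shown, and "the series" means these compounds.

Measured so far, in an ADME assay on HUVEC cells (Homo sapiens) for antiproliferative activity, read by MTT assay, with a stated time of 48 h; a higher number here means a weaker inhibitor, a lower number a stronger inhibitor:
- compound 1 `Cc1ccccc1-n1nncc1CN1C(=O)C2(C(C#N)=C(N)Oc3c(N)cc4nc5ccccc5nc4c32)c2ccccc21` gives > 50000 nM, which is a limit of this assay and not a number.
- compound 2 `CC(=O)Nc1ccc(-n2nncc2CN2C(=O)C3(C(C#N)=C(N)Oc4c(N)cc5nc6ccccc6nc5c43)c3ccccc32)cc1` gives > 50000 nM, again a limit.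
- compound 3 `CCOc1ccccc1-n1nncc1CN1C(=O)C2(C(C#N)=C(N)Oc3c(N)cc4nc5ccccc5nc4c32)c2ccccc21` gives > 50000 nM, again a limit.

Compound 3 thus stands at the limit, as do the two other values, which is what the limit of > 50000 nM in this assay, at which 3 of the 3 values shown sit, records. The steps among the measured compounds are all unreadable: a step that the two limits leave unreadable from compound 1 to compound 2, a step that the two limits leave unreadable from compound 1 to compound 3 and a step that the two limits leave unreadable from compound 2 to compound 3. None of them gives a size or a direction, so no trend in this assay can be read from the three aryl groups tried on the aromatic nitrogen.

Compound 4 `Cc1ccc(Cl)cc1-n1nncc1CN1C(=O)C2(C(C#N)=C(N)Oc3c(N)cc4nc5ccccc5nc4c32)c2ccccc21` is the next member. Its change from compound 3 is 5-chloro-2-methylphenyl in place of 2-ethoxyphenyl on an aromatic nitrogen. For the measured compounds named here, the step most closely related is the one from compound 2 to compound 3, the same position carrying a different aryl, and it too is unreadable. With every measured value sitting at the limit of this assay, the expectation for compound 4 is that it will also fall at or beyond that limit. The estimated step that the limit leaves unreadable from compound 3 to compound 4 is therefore expected to be none beyond the scatter, and compound 4 is expected to give about 60000 nM, with a range from 20000 nM to 200000 nM.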

Compound 4, half-maximal inhibitory concentration: > 50000 nM
Compound 4 was reported as a limit (the forecaster's own chance of this, stated with the estimate: 85%); the middle value does not contradict the limit.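

No new step can be read: compound 4 joins compound 1, compound 2 and compound 3 at a limit and not at a number, so its steps to all three have neither size nor direction: the limit of > 50000 nM in this assay, at which 4 of the 4 values shown sit.

The compounds shown leave open how far past that limit each one lies, and whether any aryl group on the aromatic nitrogen gives a readable value in this assay at all.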